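Removing One Trifluoromethyl Group: What to Expect for Compound 4

A few compounds are considered here, and "the series" means these few. Any claim that something is new, unique, unknown or untested is made for them only; others in the source may bear on it.

Measured so far, in a functional assay on NCI/ADR-RES cells (Homo sapiens) for inhibition, read by sulforhodamine B assay, with a stated time of 48 h; on this read-out higher numbers stand for weaker inhibition of growth and lower numbers for stronger inhibition of growth:
- compound 1 `COc1cc(-c2nn(-c3cccc(NC(=O)Nc4cc(C(F)(F)F)cc(C(F)(F)F)c4)c3)cc2-c2ccncc2)ccc1Cl` gives 1010 nM
- compound 2 `COc1cc(-c2nn(-c3cccc(NC(=O)c4cccc(C(F)(F)F)c4)c3)cc2-c2ccncc2)ccc1Cl` gives 1090 nM
- compound 3 `O=C(Nc1cccc(-n2cc(-c3ccncc3)c(-c3ccc(Cl)c(O)c3)n2)c1)Nc1cc(C(F)(F)F)cc(C(F)(F)F)c1` gives 1070 nM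

All three numbers sit close together. Compound 2 differs from compound 3 and from compound 1 by far less than the scatter, so on these numbers compound 2 cannot be told apart from either; the three compounds behave alike in this assay.

Compound 4 `COc1cc(-c2nn(-c3cccc(NC(=O)c4ccccc4)c3)cc2-c2ccncc2)ccc1Cl` has not yet been measured. Relative to compound 2 the change is hydrogen in place of trifluoromethyl on an aromatic carbon. Only one measured step exists among these compounds, a 1.1-fold higher number from compound 1 to compound 3 (0.03 log units; within the scatter), and it concerns a different place, where hydrogen replaced methyl on an oxygen; it tells little about removing a trifluoromethyl from the ring attached to the carbonyl. Compound 1 and compound 2 differ in more than one place, so their values show only that a urea carrying two trifluoromethyl groups and an amide carrying one land in the same range. For the measured compounds named here, no measured step therefore bears directly on this change. Given how little the numbers moved across the whole set, compound 4 is expected to show a step of a 1.4-fold higher number from compound 2 to compound 4 (0.14 log units; within the scatter), most likely within the scatter, with a slight lean toward a higher number. The estimate for compound 4 is 1500 nM, with a range from 600 nM to 4000 nM.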

Compound 4, concentration for 50% growth inhibition: 448 nM
For compound 4 the middle estimate is 3.3-fold (0.52 log units) above the measured one, and the stated range ends above it.
By their numbers in this assay, from the lowest: compound 4; then compounds 1, 3 and 2 (each within the scatter of the next).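

In this assay, replacing the trifluoromethyl with hydrogen gives a 2.4-fold lower number from compound 2 to compound 4 (0.39 log units; beyond the scatter), a modest step but one beyond the usual scatter, and the only step shown here that clearly moves the read-out. The earlier compounds shown here, whose values all lay close together, gave no sign that anything at this place on the ring mattered; this step shows that the change from 3-(trifluoromethyl)phenyl to phenyl does alter growth inhibition on these cells, and that the trifluoromethyl is not needed for it, since the plain benzoyl compound gives the stronger inhibition. No measurement at hand explains why this change goes with stronger inhibition.

A single pair cannot tell whether the gain is tied to the loss of trifluoromethyl in particular or whether other small groups at this place, such as a fluorine, a methyl or an amine, would give a similar number. From the compounds shown here alone, it also remains open whether the urea of compound 1 would respond in the same way to losing its trifluoromethyl groups, or whether this effect holds only for the amide.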